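The compounds below may be only part of what the source reports. "The series", "measured", "known", "first", "only" and "open" are said of these compounds alone.

Of the compounds shown here, three have been measured in a functional assay on HCT-116 cells (Homo sapiens) for inhibition, read by CCK-8 assay, with a stated time of 72 h, tested at 2 uM; a higher number here means more inhibition of growth at the concentration tested, a lower number less inhibition of growth. Compound 1 `Nc1ccccc1NC(=O)/C=C/c1ccc(CSc2ccc(Cl)cc2)cc1` gives 5.62%. Compound 2 `Cc1cc(C)cc(SCc2ccc(/C=C/C(=O)Nc3ccccc3N)cc2)c1` gives 7.98%. Compound 3 `COc1ccc(SCc2ccc(C(=O)Nc3ccccc3N)cc2)cc1` gives 73.3%, the highest of the three numbers; its nearest neighbour is compound 2, and both gaps from compound 3 lie beyond the scatter.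

Compound 4 `Nc1ccccc1NC(=O)c1ccc(CSc2cccc(F)c2)cc1` is compound 3 with one change: 3-fluorophenyl in place of 4-methoxyphenyl on a sulfur. Within the data shown here, the only measured step that also swaps the ring on the sulfur is a number 2.4 percentage points higher from compound 1 to compound 2 (within the scatter), although it was made on a different shared core. That step suggests the ring on the sulfur shifts the number little, so compound 4 is expected to land near compound 3, with a step of a number 8.3 percentage points lower from compound 3 to compound 4 (within the scatter) that stays within the scatter. The estimate for compound 4 is 65%, in the range from 35% to 88%.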

Compound 4, percent growth inhibition at one concentration: 5.5%
The estimate for compound 4 lay 59.5 percentage points above the measured number; measured number outside the range, below it.
By their numbers in this assay, from the lowest: compounds 4, 1 and 2 (each within the scatter of the next); then compound 3.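

In this assay, placing 3-fluorophenyl where 4-methoxyphenyl stood on the sulfur gives a number 67.8 percentage points lower from compound 3 to compound 4 (beyond the scatter). The ring on the sulfur can therefore decide the result on this core, which the earlier swap on a different core, a number 2.4 percentage points higher from compound 1 to compound 2 (within the scatter), did not show. No measured information accounts for this drop.

The compounds shown leave open whether the drop follows the loss of the methoxy group or the arrival of the fluorine. On these data alone, how a plain phenyl ring, or a phenyl ring bearing an amine, would read on this core also remains open.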